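Compound 1 to compound 4: adding a 4-fluorophenyl group

The compounds below may be only part of what the source reports. "The series", "measured", "known", "first", "only" and "open" are said of these compounds alone.

In a physicochemical assay for metabolic stability, read by HPLC, in phosphate buffer, at pH 7.4, tested at 10 uM (a lower number here means that the compound disappears faster, a higher number that the compound lasts longer), compound 1 (`O=C(NCCCCc1ccccc1)n1c(=O)oc2ccccc21`) gives 0.75 h and stands lowest of the three measured numbers. In this assay compound 2 (`O=C(c1ccccc1)c1ccc2c(c1)oc(=O)n2C(=O)NCCCCc1ccccc1`) gives 1.63 h and compound 3 (`O=C(c1ccc(Cl)cc1)c1ccc2c(c1)oc(=O)n2C(=O)NCCCCc1ccccc1`) gives 4.57 h on the same read-out.

The change to compound 4 (`O=C(NCCCCc1ccccc1)n1c(=O)oc2ccc(-c3ccc(F)cc3)cc21`) is 4-fluorophenyl in place of hydrogen on an aromatic carbon and in words it is 4-fluorophenyl in place of hydrogen on an aromatic carbon.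

Two measured steps start from compound 1. Benzoyl in place of hydrogen on an aromatic carbon gave a 2.2-fold higher number from compound 1 to compound 2 (0.34 log units; beyond the scatter) and (4-chlorophenyl)carbonyl in place of hydrogen on an aromatic carbon gave a 6.1-fold higher number from compound 1 to compound 3 (0.78 log units; beyond the scatter) as the larger of the two. Both are modest, and both point upward. Chloro in place of hydrogen on an aromatic carbon then gave a 2.8-fold higher number from compound 2 to compound 3 (0.45 log units; beyond the scatter) as a further modest step. For the measured compounds named here, no measured compound carries 4-fluorophenyl, and both substituted compounds carry a carbonyl that compound 4 lacks, so these steps are only a loose guide.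

A modest rise is therefore expected, nearer in size to a 2.2-fold higher number from compound 1 to compound 2 (0.34 log units; beyond the scatter) than to a 6.1-fold higher number from compound 1 to compound 3 (0.78 log units; beyond the scatter) in this series. The estimated change is a 2.4-fold higher number from compound 1 to compound 4 (0.38 log units; beyond the scatter) with a wide margin. For compound 4 the expected half-life is 1.8 h within an estimated range of 0.8 h to 4.5 h on this read-out.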

Compound 4, half-life: > 5 h
Compound 4: no number, only a limit (the forecaster's own chance of this, stated with the estimate: 5%); middle value at least 2.7-fold (0.44 log units) from the limit.
By their numbers in this assay, from the lowest: compound 1; then compound 2; then compound 3. At a limit, above all of these: compound 4.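

Compound 4 reads > 5 h in this assay, and this is a limit of the assay, not a number: the limit of > 5 h in this assay, at which 1 of the 4 values shown sits. The step to this compound is an at least 6.6-fold higher number from compound 1 to compound 4 (0.82 log units; beyond the scatter), so the half-life can rise on substitution at this aromatic carbon, meta to a fused ring and para to a fused ring, with a 4-fluorophenyl group that carries no carbonyl, whereas both earlier substituents from compound 1 brought a carbonyl with the added ring. Since the reading stops at a limit, this step fixes only a floor for the change, and the true size of the effect of 4-fluorophenyl on the core of compound 1 stays undefined.

The share of the fluorine in this rise remains open, as does the question of whether a plain phenyl at the same carbon would behave like 4-fluorophenyl, since no pair among the compounds shown separates the two. Also open, on these data alone, is whether the rise survives on the added ring with an amine or a carboxylic acid in place of the fluorine, and a value within the range of the assay would be needed to size any such change.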